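Benzyl swap on the sulfonamide nitrogen of compound 1

The source may hold more compounds than are shown below. What is called first, only, known or untested is meant among the compounds shown, and "the series" means these compounds.

In an assay on Sf9 cells for inhibition of histone deacetylase 8 (Homo sapiens), read by mobility shift assay (a lower number here means a stronger inhibitor, a higher number a weaker inhibitor), compound 1 `CC(C)(C)c1ccc(CN(C(=O)CN(Cc2c(F)c(F)c(F)c(F)c2F)S(=O)(=O)c2ccc(F)cc2)c2ccc(C(=O)NO)cc2)cc1` gives only a limit of the assay, > 1000 nM. Compound 2 `O=C(NO)c1ccc(N(Cc2ccc(C(F)(F)F)cc2)C(=O)CN(Cc2c(F)c(F)c(F)c(F)c2F)S(=O)(=O)c2ccc(F)cc2)cc1` likewise gives only a limit, > 1000 nM. The step that the two limits leave unreadable from compound 1 to compound 2 cannot be read because both values sit at the limit of > 1000 nM in this assay, at which 2 of the 2 values shown sit. Compound 3 `CC(C)(C)c1ccc(CN(C(=O)CN(Cc2ccccc2C(F)(F)F)S(=O)(=O)c2ccc(F)cc2)c2ccc(C(=O)NO)cc2)cc1` carries 2-(trifluoromethyl)phenyl in place of 2,3,4,5,6-pentafluorophenyl on a saturated chain carbon bound to a sulfonamide nitrogen. For the measured compounds named here, no measured step touches this change, and the one step recorded is unreadable, so no direction can be drawn from the series. Compound 3 is therefore expected to stay weak, with a step that the limit leaves unreadable from compound 1 to compound 3 as the estimated step. The estimate for compound 3 is 2500 nM, between 600 nM and 10000 nM, most likely reported again only as a limit.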

Compound 3, half-maximal inhibitory concentration: > 1000 nM
Compound 3: no number, only a limit (the forecaster's own chance of this, stated with the estimate: 70%); the middle value is on the limit's open side.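

Compound 3, like compound 1, gives only a limit in this assay, so no step between them can be read: the limit of > 1000 nM in this assay, at which 3 of the 3 values shown sit.

The compounds shown leave open the actual strength of all three compounds and whether either benzyl swap changes it.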